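This account rests on a few compounds, and the source may have more. Where it says the series, first, only, none or still open, it means among the compounds named here.

Compound 1 `O=C1COc2ccc(-c3nn(-c4ccc(F)cc4)cc3-c3ccccc3)cc2N1` gives 78.2% in a functional assay on A549 cells (Homo sapiens) for cytotoxicity, read by colorimetric assay and MTT assay, with a stated time of 3 days, tested at 1 uM; a lower number here means a stronger effect, a higher number a weaker effect of the compound at the concentration tested.
Compound 2 `O=C1COc2ccc(-c3nn(-c4ccc(Cl)cc4)cc3-c3ccccc3)cc2N1` gives 84.4% in this assay.
Compound 3 `COc1ccc(-n2cc(-c3ccccc3)c(-c3ccc4c(c3)NC(=O)CO4)n2)cc1` gives 95.6% in this assay.

Compound 3 gives the highest of the three numbers in this assay, standing beyond the scatter above both compound 2 and compound 1. Compound 4 `O=C1COc2ccc(-c3nn(-c4ccccc4)cc3-c3ccccc3)cc2N1` differs from it by hydrogen in place of methoxy on an aromatic carbon. Within the data shown here, two measured steps bear on this change: a number 17.4 percentage points higher from compound 1 to compound 3 (beyond the scatter) and a number 11.2 percentage points higher from compound 2 to compound 3 (beyond the scatter). Both show that the methoxy compound gives a higher number than either halogen compound, while a number 6.2 percentage points higher from compound 1 to compound 2 (within the scatter) is within the scatter. Removing the methoxy is therefore expected to lower the number by a modest step, a number 11.6 percentage points lower from compound 3 to compound 4 (beyond the scatter), toward the values of compound 1 and compound 2. Compound 4 is estimated at 84%, with a range from 72% to 96%.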

Compound 4, a percentage reported as activity, at one concentration (the size of the read-out at that concentration, not a potency): 92.2%
Compound 4: the middle estimate sits 8.2 percentage points below what was measured; measured number inside the range.
By their numbers in this assay, from the lowest: compounds 1, 2, 4 and 3 (each within the scatter of the next, the first and the last beyond it).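

In this assay, going from 4-methoxyphenyl to phenyl gives a number 3.4 percentage points lower from compound 3 to compound 4 (within the scatter), so at this position the data do not separate hydrogen from methoxy. Hydrogen is likewise not separated from chloro, with a number 7.8 percentage points higher from compound 2 to compound 4 (within the scatter), whereas a number 14 percentage points higher from compound 1 to compound 4 (beyond the scatter) sets fluoro apart from hydrogen, as it is from methoxy. Nothing available offers an explanation for this pattern. On these data alone, whether an amine, a carboxylic acid or a longer chain such as butoxy at this position would fall outside the span of these four compounds remains open.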